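This account rests on a few compounds, and the source may have more. Where it says the series, first, only, none or still open, it means among the compounds named here.

Measured so far:

In a functional assay on DU-145 cells (Homo sapiens) for inhibition, read by MTT assay, with a stated time of 24 h (on this read-out higher numbers stand for weaker inhibition and lower numbers for stronger inhibition), compound 1 `CCOC(=O)C1=Cc2ccccc2OC1(OCc1cn(-c2ccc(F)cc2)nn1)C(F)(F)F` gives 8900 nM.
In this assay compound 2 `CCOC(=O)C1=Cc2ccccc2OC1(OCc1cn(CC(=O)Nc2cccc(Cl)c2)nn1)C(F)(F)F` gives 10100 nM.
Compound 3 `CCOC(=O)C1=Cc2ccccc2OC1(OCc1cc(-c2ccc(C)cc2)no1)C(F)(F)F` gives only a limit in this assay, namely > 150000 nM.

Compound 2 holds the higher of the two plain numbers, but its step of a 1.1-fold higher number from compound 1 to compound 2 (0.05 log units; within the scatter) lies within the usual scatter, so compound 1 and compound 2 cannot be told apart. The value of compound 3 is a limit and gives no number to compare.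

Compound 4 `CCCCCCCCn1cc(COC2(C(F)(F)F)Oc3ccccc3C=C2C(=O)OCC)nn1` is the next compound to be measured. It differs from compound 2 by heptyl in place of (3-chlorophenyl)carbamoyl on a saturated chain carbon bound to an aromatic nitrogen. Within the data shown here, no measured step matches this exchange of an aryl amide for a plain chain on the same saturated carbon. Among the measured compounds shown here, the only measured step, from compound 1 to compound 2, swapped two groups on that nitrogen and stayed within the scatter, and the limit of compound 3 the limit of > 150000 nM in this assay, at which 1 of the 3 values shown sits, arose from a change of the five-membered ring, not of this substituent. With nothing pointing to a shift, the expected step of a 1.1-fold lower number from compound 2 to compound 4 (0.05 log units; within the scatter) is none beyond the scatter. Compound 4 is therefore estimated at 9000 nM, between 3000 nM and 30000 nM.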

Compound 4, half-maximal inhibitory concentration: > 150000 nM
Compound 4: only a limit was reported; the forecaster's own chance of this, stated with the estimate: 12%; middle value at least 16-fold (1.22 log units) from the limit.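

The group on the aromatic nitrogen cannot be exchanged freely after all: in this assay octyl in place of 4-fluorophenyl gives an at least 16-fold higher number from compound 1 to compound 4 (1.22 log units; beyond the scatter) and heptyl in place of (3-chlorophenyl)carbamoyl gives an at least 14-fold higher number from compound 2 to compound 4 (1.17 log units; beyond the scatter) while the earlier swap gave only a 1.1-fold higher number from compound 1 to compound 2 (0.05 log units; within the scatter) on the same nitrogen. Compound 4 gives > 150000 nM as a limit of the assay and not a number. The two groups that kept a measurable value each carry a six-membered aromatic ring and octyl carries none, but compound 3 goes against any simple ring rule, holding such a ring and still sitting at a limit: the limit of > 150000 nM in this assay, at which 2 of the 4 values shown sit.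

The compounds shown do not separate the missing ring from the length of the chain. A short ethyl chain, a benzyl group or a chain ending in an amine would help to tell these apart.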